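Aryl variation on the ring nitrogen: step toward compound 4

The compounds below may be only part of what the source reports. "The series", "measured", "known", "first", "only" and "open" are said of these compounds alone.

The series shares one core carrying a 2-hydroxyphenyl group and a trifluoromethyl-substituted hydroxyphenyl group, varied at the aryl group on an aromatic nitrogen. Compound 1 `Cc1ccc(-n2nc(-c3ccc(C(F)(F)F)cc3O)nc2-c2ccccc2O)cc1` gives 71.5% in a functional assay on PC-12 cells (Rattus norvegicus) for cytotoxicity, read by MTT assay, with stated times of 2 h and 24 h, tested at 1 uM; on this read-out higher numbers stand for a stronger effect at the one concentration tested and lower numbers for a weaker effect. Compound 2 `CC(C)c1ccc(-n2nc(-c3ccc(C(F)(F)F)cc3O)nc2-c2ccccc2O)cc1` gives 69.7% in the same read-out. Compound 3 `Oc1cc(C(F)(F)F)ccc1-c1nc(-c2ccccc2O)n(-c2ccccc2F)n1` gives 63.4% in this assay; its number sits with those of compounds 1 and 2 within the scatter, so no order among the three is established. The two steps that reach compound 3 are the only ones that touch the same position: a number 8.1 percentage points lower from compound 1 to compound 3 (within the scatter) and a number 6.3 percentage points lower from compound 2 to compound 3 (within the scatter), both within the scatter.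

Compound 4 `Oc1cc(C(F)(F)F)ccc1-c1nc(-c2ccccc2O)n(-c2cccc(C(F)(F)F)c2)n1` is not yet measured. It differs from compound 3 in one place: 3-(trifluoromethyl)phenyl in place of 2-fluorophenyl on an aromatic nitrogen. The two recorded exchanges of the aryl group on the aromatic nitrogen, methyl- or isopropyl-substituted phenyl against 2-fluorophenyl, moved this assay by amounts within the scatter, and nothing measured separates a 3-(trifluoromethyl)phenyl from those groups. The expectation for compound 4 is therefore a step of about a number 2.6 percentage points higher from compound 3 to compound 4 (within the scatter), that is no change beyond the scatter in either direction. Compound 4 is estimated at 66% in this assay, expected between 52% and 80%.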

Compound 4, a percentage reported as activity, at one concentration (the size of the read-out at that concentration, not a potency): 71.5%
For compound 4 the middle estimate is 5.5 percentage points below the measured one, and the stated range covers the measured number.
By their numbers in this assay, from the lowest: compounds 3, 2, 1 and 4 (each within the scatter of the next).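

The exchange of 2-fluorophenyl for 3-(trifluoromethyl)phenyl, with 10 heavy atoms entering in place of 7, gives a number 8.1 percentage points higher from compound 3 to compound 4 (within the scatter) in this assay, so this larger fluorinated aryl group on the aromatic nitrogen is accommodated without a change beyond the scatter. Against the alkyl-substituted phenyl groups, the record reads a number 1.8 percentage points higher from compound 2 to compound 4 (within the scatter) and no change at the digits printed from compound 1 to compound 4 (within the scatter), which places all four aryl groups at this position within the scatter of one another, with fluorinated and alkyl-substituted rings not separated by this read-out. The compounds shown offer no measured evidence on what lies behind this flat response.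

Going by these compounds, every group at this position is a substituted phenyl, so it remains open whether a phenyl bearing an amine or a carboxylic acid, or a benzyl or cyclohexyl group in its place, would move the number beyond the scatter. The two hydroxyl groups also stay the same throughout, which leaves open what a methoxy group in place of either would do, and the single tested concentration leaves any difference in potency among these compounds unresolved.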